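This account rests on a few compounds, and the source may have more. Where it says the series, first, only, none or still open, it means among the compounds named here.

Working notes on the series. Compound 1 `CC(=O)c1ccccc1OCc1ccc2no[n+]([O-])c2c1` and compound 3 `N=C(N)N/N=C\c1ccccc1OCc1ccc2no[n+]([O-])c2c1` share one core; compound 2 `CC(=O)c1ccccc1OCc1ccc2c(c1)=[N+]([O-])C(C)(C)[N+]=2[O-]` and compound 4 `CC1(C)[N+]([O-])=c2ccc(COc3ccccc3/C=N\NC(=N)N)cc2=[N+]1[O-]` share another. The difference between the two cores is not broken down here.

In an ADME assay on cells (Erythrocyte, Homo sapiens), read by spectrophotometry and hemolysis, with a stated time of 24 h (on this read-out higher numbers stand for weaker inhibition and lower numbers for stronger inhibition), compound 1 gives only a limit, > 200 uM. Compound 3 gives 58 uM. The step of an at least 3.4-fold lower number from compound 1 to compound 3 (0.53 log units; beyond the scatter) comes with the change a group of 6 heavy atoms (2 carbon, 4 nitrogen; no ring) in place of a group of 3 heavy atoms (2 carbon, 1 oxygen; no ring), on an aromatic carbon and can only be set as a bound due to the limit of > 200 uM in this assay, at which 1 of the 3 values shown sits.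

Compound 2 also gives only a limit in this assay, < 50 uM. Compound 4 carries the same change on the second core, (a group of 6 heavy atoms (2 carbon, 4 nitrogen; no ring) in place of a group of 3 heavy atoms (2 carbon, 1 oxygen; no ring), on an aromatic carbon). It is expected that compound 4 sits lower than its parent, with a step that the limit leaves unreadable from compound 2 to compound 4. This expectation rests on the measured step of an at least 3.4-fold lower number from compound 1 to compound 3 (0.53 log units; beyond the scatter). The starting point is only a bound, (the limit of < 50 uM in this assay, at which 1 of the 3 values shown sits), so the size is uncertain. Compound 4 is estimated at 25 uM, between 8 uM and 70 uM.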

Compound 4, concentration for 50% inhibition: 114 uM
The estimate for compound 4 lay 4.6-fold (0.66 log units) below the measured number, outside the stated range (above it).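

On the core of compound 2, replacing acetyl gives an at least 2.2-fold higher number from compound 2 to compound 4 (0.35 log units; beyond the scatter) in this assay, and the change does not carry its direction over from the core of compound 1: the same change on two cores in this assay, an at least 3.4-fold lower number (0.53 log units; beyond the scatter) from compound 1 to compound 3 and an at least 2.2-fold higher number (0.35 log units; beyond the scatter) from compound 2 to compound 4, at least 7.8-fold (0.89 log units) apart, beyond the scatter of two such steps

Compound 2 gives only a limit, < 50 uM, so the step from it is a bound and not a measured size. Compound 1 also gives only a limit, > 200 uM; the direction of each step is set, their true sizes are not, and two pairs do not show which feature of the two cores decides the direction.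

Going by these compounds, it remains open whether the opposite directions on the two cores would hold for other groups on the same aromatic carbon, such as an amine or a carboxylic acid in place of acetyl. On these data alone, it is also open whether the gap between the two steps would keep its size if the acetyl compounds on both cores had exact values instead of limits.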